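Swapping Methoxy for Acetoxymethyl on a Carbonyl Carbon

The source may report more compounds than this note shows. Statements on the series, on what has been measured and on what is new or still open speak of the compounds shown alone.

Among the measured compounds shown here, compound 2 `COC(=O)N1N=C(c2ccc(N(C)C)cc2)OC1c1cc(OC)c(OC)c(OC)c1` gives 106 uM in a functional assay on NCI-H460 cells (Homo sapiens) (a lower number here means that less compound is needed, a higher number that more compound is needed for the effect), and so holds the higher of the two numbers so far. Compound 1 `CCOC(=O)C(=O)N1N=C(c2ccc(N(C)C)cc2)OC1c1cc(OC)c(OC)c(OC)c1` gives 33 uM and differs from it in one place only. Compound 3 `COc1cc(C2OC(c3ccc(N(C)C)cc3)=NN2C(=O)COC(C)=O)cc(OC)c1OC` has acetoxymethyl in place of methoxy on a carbonyl carbon, and acetoxymethyl in place of methoxy on a carbonyl carbon sums up that swap in counts. For the measured compounds named here, only one measured step bears on this change, and a 3.2-fold higher number from compound 1 to compound 2 (0.51 log units; beyond the scatter) is modest yet beyond the scatter. Acetoxymethyl resembles the ethoxycarbonyl of compound 1 at 33 uM in being larger than methoxy, so a lower number is expected. The expected move is a 1.9-fold lower number from compound 2 to compound 3 (0.28 log units; within the scatter) and it rests on thin evidence. Compound 3 is estimated at 55 uM within an expected range of 15 uM to 170 uM in this assay once measured.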

Compound 3, concentration for half-maximal effect: 0.072 uM
Compound 3: the middle estimate sits 760-fold (2.88 log units) above what was measured; measured number outside the range, below it.
By their numbers in this assay, from the lowest: compound 3; then compound 1; then compound 2.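

At this position, on a carbonyl carbon whose other neighbour is an amide-type nitrogen in a ring, acetoxymethyl gives in this assay both a 1500-fold lower number from compound 2 to compound 3 (3.17 log units; beyond the scatter) and a 460-fold lower number from compound 1 to compound 3 (2.66 log units; beyond the scatter). Among the compounds shown here, both new steps are large, while the only earlier step, a 3.2-fold higher number from compound 1 to compound 2 (0.51 log units; beyond the scatter), is modest, so the two earlier compounds gave no sign of how far a change at this one place can move the number. Nothing available explains why acetoxymethyl has so large an effect here.

From the compounds shown here alone, what remains open is which part of acetoxymethyl matters: hydroxymethyl, plain methyl or a longer chain such as propionyloxymethyl on the same carbonyl would help separate the ester from the rest of the group. Going by these compounds, it is also open whether an amine in this place would keep the number this low.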